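From Ethoxy to Trifluoromethoxy on a Shared Core

The source may report more compounds than this note shows. Statements on the series, on what has been measured and on what is new or still open speak of the compounds shown alone.

Compound 3 `CCOc1cc2[nH]ncc2cc1-c1ccccc1C(F)(F)F` is one of three measured compounds built on a shared core. In an assay on CHO-TREX cells for antagonist activity at transient receptor potential cation channel subfamily A member 1 (Homo sapiens), read by FLIPR and calcium flux, with a stated time of 10 min (on this read-out higher numbers stand for weaker inhibition and lower numbers for stronger inhibition), compound 3 gives 39 nM, the second highest of the three numbers. Closest to it is compound 2 `COc1cc2[nH]ncc2cc1-c1ccccc1C(F)(F)F`, which gives 26 nM; the step of a 1.5-fold higher number from compound 2 to compound 3 (0.18 log units; within the scatter) lies within the scatter. Furthest away is compound 1 `CC(C)c1cc2[nH]ncc2cc1-c1ccccc1C(F)(F)F`, which gives 25400 nM; the step of a 650-fold lower number from compound 1 to compound 3 (2.81 log units; beyond the scatter), like a 980-fold lower number from compound 1 to compound 2 (2.99 log units; beyond the scatter), is large. Compound 4 `FC(F)(F)Oc1cc2[nH]ncc2cc1-c1ccccc1C(F)(F)F` differs from compound 3 by trifluoromethyl in place of ethyl on an oxygen on an aromatic ring. Going by the values given here, only one measured step touches this oxygen, a 1.5-fold higher number from compound 2 to compound 3 (0.18 log units; within the scatter), and it stayed within the scatter; no measured step involves fluorine at all. For compound 4 a small step is expected, a 1.5-fold higher number from compound 3 to compound 4 (0.19 log units; within the scatter), not clearly beyond the scatter. Compound 4 is estimated at 60 nM, with a range from 20 nM to 200 nM.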

Compound 4, half-maximal inhibitory concentration: 36 nM
The estimate for compound 4 lay 1.7-fold (0.22 log units) above the measured number; the range from low to high includes it.
By their numbers in this assay, from the lowest: compounds 2, 4 and 3 (each within the scatter of the next); then compound 1.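

At this oxygen on an aromatic ring, trifluoromethyl takes the place of ethyl or methyl with the number staying within the scatter, as a 1.1-fold lower number from compound 3 to compound 4 (0.03 log units; within the scatter) and a 1.4-fold higher number from compound 2 to compound 4 (0.14 log units; within the scatter) show. Fluorine on this group thus leaves the reading level with the two plain chains, and the one large step here remains that from the isopropyl compound (a 710-fold lower number from compound 1 to compound 4 (2.85 log units; beyond the scatter)). Nothing measured here accounts for why these three groups read alike. Still open, as far as these compounds go, is how an amine, a hydroxyl or a longer chain such as butoxy would read in this place.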